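The compounds below may be only part of what the source reports. "The series", "measured", "known", "first", "only" and "open" are said of these compounds alone.

Measured compounds, all in an ADME assay on Huh-7 cells (Homo sapiens) for cytotoxicity, with a stated time of 72 h; on this read-out lower numbers stand for higher toxicity in this test and higher numbers for lower toxicity in this test:
Compound 1 `COC(=O)n1c(=O)c(C)cn([C@@H]2O[C@H](CO[Si](C)(C)C(C)(C)C)[C@@]3(OS(=O)(=O)C=C3N)[C@H]2O[Si](C)(C)C(C)(C)C)c1=O` gives > 100000 nM, a limit of the assay.
Compound 2 `Cc1cn([C@@H]2O[C@H](CO[Si](C)(C)C(C)(C)C)[C@@]3(OS(=O)(=O)C=C3N)[C@H]2O[Si](C)(C)C(C)(C)C)c(=O)n(C(=O)CCCBr)c1=O` gives > 100000 nM, a limit of the assay.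
Compound 3 `Cc1cn([C@@H]2O[C@H](CO[Si](C)(C)C(C)(C)C)[C@@]3(OS(=O)(=O)C=C3N)[C@H]2O[Si](C)(C)C(C)(C)C)c(=O)n(C(=O)CCCC(N)=O)c1=O` gives > 100000 nM, a limit of the assay.

Among the measured compounds shown here, compound 2 therefore stands on the numbers only as a limit, and the two further values shown for this assay are limits as well, so no measured compound has a readable position. The step to compound 4 `CSC(=O)CCCC(=O)n1c(=O)c(C)cn([C@@H]2O[C@H](CO[Si](C)(C)C(C)(C)C)[C@@]3(OS(=O)(=O)C=C3N)[C@H]2O[Si](C)(C)C(C)(C)C)c1=O` is (methylsulfanyl)carbonyl in place of bromo on a saturated chain carbon, three bonds along the chain from a carbonyl carbon. For the measured compounds named here, three measured steps bear on this place on the chain: a step that the two limits leave unreadable from compound 1 to compound 2; a step that the two limits leave unreadable from compound 1 to compound 3; a step that the two limits leave unreadable from compound 2 to compound 3. None of them can be read because of the limit of > 100000 nM in this assay, at which 3 of the 3 values shown sit. Neither a 3-bromopropyl nor a 3-carbamoylpropyl on the carbonyl carbon, nor the exchange of bromo for carbamoyl on the saturated chain carbon three bonds along the chain from a carbonyl carbon, moved any value off that limit. A (methylsulfanyl)carbonyl in place of bromo at the same chain carbon is thus expected to give no step beyond the scatter, a number no higher from compound 2 to compound 4 (the limit leaves the size open). Compound 4 is estimated at 100000 nM in this assay, within 50000 nM to 200000 nM, and most probably reported once more only as a limit.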

Compound 4, half-maximal cytotoxic concentration: > 100000 nM
Compound 4 ended at the assay's limit; the forecaster's own chance of this, stated with the estimate: 85%; the middle value lies on the limit itself.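

Compound 4 sits at the same assay limit in this assay as compound 1, compound 2 and compound 3, so none of its steps to these compounds can be read: the limit of > 100000 nM in this assay, at which 4 of the 4 values shown sit. The compounds shown leave open how far each lies beyond that limit, and whether any change on this chain would give a readable value.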